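The source may hold more compounds than are shown below. What is called first, only, known or untested is meant among the compounds shown, and "the series" means these compounds.

Measured so far in a functional assay on HUVEC cells (Homo sapiens) for antiproliferative activity, read by MTT assay, with a stated time of 48 h; on this read-out lower numbers stand for stronger inhibition and higher numbers for weaker inhibition:
- compound 1 `CCN(CC)CC(=O)Nc1ccc(Nc2nc(-c3ccc(OC)cc3)nc(Cl)c2-c2ccccc2)cc1`: > 40000 nM (a limit, not a number)
- compound 2 `COc1ccc(-c2nc(Cl)cc(Nc3ccc(NC(=O)CN(C)C)cc3)n2)cc1`: > 40000 nM (a limit, not a number)

In this assay compound 2 has no number, only the limit > 40000 nM. Among the measured compounds shown here, the same holds across the series so far: the limit of > 40000 nM in this assay, at which 2 of the 2 values shown sit. Compound 1 likewise gives only a limit, > 40000 nM.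

The next compound, compound 3 `COc1ccc(-c2nc(Cl)c(-c3ccccc3)c(Nc3ccc(NC(=O)CN(C)C)cc3)n2)cc1`, differs from compound 2 by one change: phenyl in place of hydrogen on an aromatic carbon. In words, a phenyl group takes the place of hydrogen on an aromatic carbon, ortho to a chloro group.

For the measured compounds named here, no measured step gives the size of such a change, and with only limits in hand, no direction is favoured. The expected a number no higher from compound 2 to compound 3 (the limit leaves the size open) is therefore none beyond the usual scatter, and another report as a limit in this assay is the likeliest outcome. Compound 3 is estimated at 40000 nM, with an expected range from 15000 nM to 80000 nM.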

Compound 3, half-maximal inhibitory concentration: 10400 nM
For compound 3 the middle estimate is 3.8-fold (0.59 log units) above the measured one; the whole stated range lies above it.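

In this assay, among the compounds shown here, phenyl in place of hydrogen on the aromatic carbon ortho to a chloro group gives an at least 3.8-fold lower number from compound 2 to compound 3 (0.58 log units; beyond the scatter), the first step that can be read with a direction. With phenyl on that carbon in both compounds, dimethylamino in place of diethylamino on the saturated chain carbon bound to a carbonyl carbon gives an at least 3.8-fold lower number from compound 1 to compound 3 (0.58 log units; beyond the scatter), so the end of the side chain also counts in this setting. Both steps start from a limit, so neither has a full size, and compound 3 alone carries a number: the limit of > 40000 nM in this assay, at which 2 of the 3 values shown sit.

The compounds shown leave open whether the aromatic ring of the phenyl group is needed on this carbon, which a methyl group or a fluorophenyl group in the same place would test. From the compounds shown here alone, it also remains open how the read-out follows the amine at the end of the chain, for instance with a morpholine or a primary amine in place of dimethylamino, and whether either change would move the number further down.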